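A few compounds are considered here, and "the series" means these few. Any claim that something is new, unique, unknown or untested is made for them only; others in the source may bear on it.

Compound 1 `CC(=O)OC/C1=C/C[C@](C)(CCC=C(C)C)/C=C/[C@@H](OC(=O)C=C(C)C)[C@](C)(O)/C=C/C1=O`: 2950 nM
Compound 2 `CC(C)=CCC[C@]1(C)/C=C/[C@@H](OC(=O)C=C(C)C)[C@](C)(O)/C=C/C(=O)/C(CN(C)C)=C\C1`: 140 nM
Compound 3 `CC(C)=CCC[C@]1(C)/C=C/[C@@H](OC(=O)C=C(C)C)[C@](C)(O)/C=C/C(=O)/C(Cn2cc(CO)nn2)=C\C1`: 3200 nM

All three values come from a functional assay on HL-60 cells (Homo sapiens) for antiproliferative activity, read by MTT assay, with a stated time of 48 h; a lower number here means a stronger inhibitor, a higher number a weaker inhibitor. The triazole compound sits level with the acetoxy compound, as shown by a 1.1-fold higher number from compound 1 to compound 3 (0.04 log units; within the scatter). Set against the dimethylamino compound, the picture differs sharply, with a 23-fold higher number from compound 2 to compound 3 (1.36 log units; beyond the scatter).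

The next compound is compound 4 `CO/N=C/C1=C/C[C@](C)(CCC=C(C)C)/C=C/[C@@H](OC(=O)C=C(C)C)[C@](C)(O)/C=C/C1=O`, and the change is a group of 4 heavy atoms (2 carbon, 1 nitrogen, 1 oxygen; no ring) in place of a group of 8 heavy atoms (4 carbon, 3 nitrogen, 1 oxygen; one five-membered aromatic ring with 3 hetero atoms), on a double-bonded ring carbon. Among the compounds with values here, no measured compound carries the entering group, so the measured steps bear on this change only indirectly. Exchanging acetoxy for the triazole group gave a 1.1-fold higher number from compound 1 to compound 3 (0.04 log units; within the scatter), which is within the scatter. Only the dimethylamino group produced a large shift, with a 21-fold lower number from compound 1 to compound 2 (1.32 log units; beyond the scatter). Compound 4 lacks that group, so it is expected to stay close to the other two compounds without it, although three compounds are a thin basis. The expected result is a 1.3-fold lower number from compound 3 to compound 4 (0.11 log units; within the scatter), a step not expected to exceed the scatter in this assay. For compound 4 the estimated value is 2500 nM, with an expected range of 800 nM to 7000 nM.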

Compound 4, half-maximal inhibitory concentration: 4760 nM
Estimate against measurement, compound 4: 1.9-fold (0.28 log units) below, and the stated range covers the measured number.
By their numbers in this assay, from the lowest: compound 2; then compounds 1, 3 and 4 (each within the scatter of the next).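

In this assay the group that enters on the double-bonded ring carbon in compound 4, which has no ring and no hydrogen-bond donors, stays level with both the triazole-bearing group (a 1.5-fold higher number from compound 3 to compound 4 (0.17 log units; within the scatter)) and the acetoxy group (a 1.6-fold higher number from compound 1 to compound 4 (0.21 log units; within the scatter)). The dimethylamino group remains the only one set apart (a 34-fold higher number from compound 2 to compound 4 (1.53 log units; beyond the scatter)), even though the entering group and the group it replaces in this step each count 4 heavy atoms and each hold a nitrogen, so neither that count nor the presence of nitrogen tracks the gap. Nothing available here accounts for that gap.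

As far as these compounds go, whether the large step belongs to the dimethylamino group alone or extends to other amines stays open. A pyrrolidine, a morpholine or a primary amine on the same carbon could either match compound 2 or join the other three.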